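From 2-methylpyridin-3-yl to 4-methylthiophen-3-yl in compound 3

A few compounds are considered here, and "the series" means these few. Any claim that something is new, unique, unknown or untested is made for them only; others in the source may bear on it.

In a functional assay on MCF7 cells (Homo sapiens) for cytotoxicity, read by CellTiter-Glo, with a stated time of 5 days (on this read-out higher numbers stand for weaker inhibition and lower numbers for stronger inhibition), compound 1 `CC/C(=C(/c1ccc(/C=C/C(=O)O)cc1)c1ccc2[nH]ncc2c1)c1ccccc1` gives 6 nM and compound 2 `CC/C(=C(/c1ccc(/C=C/C(=O)O)cc1)c1ccc2[nH]ncc2c1)c1cccnc1C` gives 200 nM as the higher of the two numbers. Compound 3 `CC/C(=C(/c1ccc(/C=C/C(=O)O)cc1)c1ccc2[nH]ncc2c1)c1cscc1C` differs from compound 2 in one group: 4-methylthiophen-3-yl in place of 2-methylpyridin-3-yl on a double-bonded chain carbon bound to a double-bonded chain carbon and a saturated chain carbon with 4-methylthiophen-3-yl in place of 2-methylpyridin-3-yl on a double-bonded chain carbon bound to a double-bonded chain carbon and a saturated chain carbon.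

Among the compounds with values here, only one measured step bears on this place: a 33-fold higher number from compound 1 to compound 2 (1.52 log units; beyond the scatter) for 2-methylpyridin-3-yl in place of phenyl, a large step beyond the scatter. Within the data shown here, compounds 1 and 2 do not separate the methyl from the ring nitrogen, and no measured compound carries a 4-methylthiophen-3-yl group. Compound 3 keeps a methyl and has no ring nitrogen, so recovery of part of a 33-fold higher number from compound 1 to compound 2 (1.52 log units; beyond the scatter) is expected, but not all of it. The expected change is a 5.0-fold lower number from compound 2 to compound 3 (0.70 log units; beyond the scatter) in this assay as a moderate move to a lower number. For compound 3 the estimated value is 40 nM with an expected range from 10 nM to 160 nM in this estimate.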

Compound 3, half-maximal inhibitory concentration: 2 nM
For compound 3 the middle estimate is 20-fold (1.30 log units) above the measured one; measured number outside the range, below it.
By their numbers in this assay, from the lowest: compound 3; then compound 1; then compound 2.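

In this assay, the place on a double-bonded chain carbon bound to a double-bonded chain carbon and a saturated chain carbon proves to accept a methyl-bearing aromatic ring with no loss, as 4-methylthiophen-3-yl in place of phenyl gives a 3.0-fold lower number from compound 1 to compound 3 (0.48 log units; beyond the scatter) and so falls below the unsubstituted phenyl. Exchanging the six-membered nitrogen ring for the five-membered sulfur ring gives a 100-fold lower number from compound 2 to compound 3 (2.00 log units; beyond the scatter) and leaves compound 2 as the only one of the three on the high side, so a ring methyl alone does not go with a high number in this small set. The evidence available gives no explanation for either step.

The compounds shown do not separate the contributions of the methyl, the hetero atom and the ring size, since compound 3 differs from compound 1 and from compound 2 in more than one of these features at once. A 2-methylphenyl, a plain pyridin-3-yl or a plain thiophen-3-yl at this place would help to tell these contributions apart.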